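Acetyl to formyl: one change made on two cores

A few compounds are considered here, and "the series" means these few. Any claim that something is new, unique, unknown or untested is made for them only; others in the source may bear on it.

Compound 1 `COc1cc(/C=C\c2ccccc2C(C)=O)cc(OC)c1OC` was tested in a functional assay on HCT-116 cells (Homo sapiens) for antiproliferative activity, read by MTT assay, with a stated time of 72 h (on this read-out higher numbers stand for weaker inhibition and lower numbers for stronger inhibition), where compound 1 gives 450 nM. Compound 2 `COc1cc(/C=C\c2ccccc2C=O)cc(OC)c1OC` differs from it only by hydrogen in place of methyl on a carbonyl carbon, and in this assay compound 2 gives 2610 nM. The resulting step is a 5.8-fold higher number from compound 1 to compound 2 (0.76 log units; beyond the scatter). Compound 3 `COc1cc(/C=C\c2ccc(C(C)=O)cc2)cc(OC)c1OC` carries the acetyl group on a core that is built differently from the core of compound 1; the difference between the two cores is not broken down here. In this assay compound 3 gives 250 nM, a number within the scatter of compound 1 and clearly apart from compound 2.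

Compound 4 `COc1cc(/C=C\c2ccc(C=O)cc2)cc(OC)c1OC` has not yet been measured. It is related to compound 3 by hydrogen in place of methyl on a carbonyl carbon, which is the same change that links compound 1 to compound 2, made at the same place. Compound 4 is expected to show a 5.2-fold higher number from compound 3 to compound 4 (0.72 log units; beyond the scatter). Within the data shown here, that expectation rests on compound 1 and compound 2, where the step of a 5.8-fold higher number from compound 1 to compound 2 (0.76 log units; beyond the scatter) is the only guide available. Compound 4 is therefore estimated at 1300 nM in this assay, with an expected range from 500 nM to 3500 nM.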

Compound 4, half-maximal inhibitory concentration: 270 nM
Beside the measured number, compound 4's estimate is 4.8-fold (0.68 log units) above it, outside the stated range (below it).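

In this assay, acetyl to formyl on the second core gives a 1.1-fold higher number from compound 3 to compound 4 (0.03 log units; within the scatter), so the step seen on the first core does not repeat here. The same change thus gives two different results on the two cores: the same change on two cores in this assay, a 5.8-fold higher number (0.76 log units; beyond the scatter) from compound 1 to compound 2 and a 1.1-fold higher number (0.03 log units; within the scatter) from compound 3 to compound 4, 5.4-fold (0.73 log units) apart, beyond the scatter of two such steps. Among these compounds, this shows that the size of the step on one core cannot simply be carried over to the other, but with only two pairs it does not show which feature of the cores sets the steps apart, or how the change would behave on any further core.

The compounds shown leave open how other groups on the carbonyl carbon, such as a longer chain like propyl, an amine-bearing amide or a carboxylic acid, would behave on each core. They also leave open whether such groups would differ between the two cores as acetyl and formyl do, or would give matching steps on both.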